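The compounds below may be only part of what the source reports. "The series", "measured", "known", "first", "only" and "open" are said of these compounds alone.

Measured so far in an assay on isolated protein for inhibition of Amine oxidase [flavin-containing] A (Homo sapiens), read by fluorescence and Amplex Red, with a stated time of 30 min; on this read-out higher numbers stand for weaker inhibition and lower numbers for stronger inhibition:
compound 1 `CCCCNc1nnc(SCC(=O)N(Cc2cccc([N+](=O)[O-])c2)c2ccc(F)cc2)s1`, 1180 nM
compound 2 `CC(C)CNc1nnc(SCC(=O)N(Cc2cccc([N+](=O)[O-])c2)c2ccc(F)cc2)s1`, 1790 nM
compound 3 `COCCNc1nnc(SCC(=O)N(Cc2cccc([N+](=O)[O-])c2)c2ccc(F)cc2)s1`, 60 nM

Compound 3 holds the lowest number of the three. The steps of a 20-fold lower number from compound 1 to compound 3 (1.29 log units; beyond the scatter) and a 30-fold lower number from compound 2 to compound 3 (1.47 log units; beyond the scatter) are both large, whereas a 1.5-fold higher number from compound 1 to compound 2 (0.18 log units; within the scatter) stays within the scatter, so the two plain alkyl chains read alike and the methoxy-bearing chain stands apart. The next compound, compound 4 `C=CCNc1nnc(SCC(=O)N(Cc2cccc([N+](=O)[O-])c2)c2ccc(F)cc2)s1`, carries this change: vinyl in place of methoxymethyl on a saturated chain carbon bound to a nitrogen on an aromatic ring. The chain loses the hydrogen-bond acceptor of the methoxymethyl group and comes to resemble the chains of compound 1 and compound 2, whose numbers sit well above that of compound 3. Both large steps bear on this move, each pointing toward the methoxy-bearing chain, so the reverse is expected here: a large step upward in this assay, roughly undoing those gains, and for compound 4 the expected step is a 12-fold higher number from compound 3 to compound 4 (1.07 log units; beyond the scatter). Compound 4 is therefore estimated at about 700 nM, with a plausible range from 200 nM to 2500 nM.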

Compound 4, half-maximal inhibitory concentration: 502 nM
The estimate for compound 4 lay 1.4-fold (0.14 log units) above the measured number; low and high end bracket the measured number.
By their numbers in this assay, from the lowest: compound 3; then compound 4; then compounds 1 and 2 (each within the scatter of the next).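

In this assay, the allyl chain falls in the middle of the set: an 8.4-fold higher number from compound 3 to compound 4 (0.92 log units; beyond the scatter) shows that it does not hold the level of the 2-methoxyethyl chain, while a 2.4-fold lower number from compound 1 to compound 4 (0.37 log units; beyond the scatter) and a 3.6-fold lower number from compound 2 to compound 4 (0.55 log units; beyond the scatter) show that it does not read like the two plain alkyl chains either. This position is therefore not a simple split between the methoxy-bearing chain and chains without oxygen, as one chain without oxygen closes part of the gap. Nothing available explains these differences.

Open, on these data alone, is whether the double bond or the shorter chain separates allyl from the alkyl chains, a question a plain propyl chain would address. Also open, as far as these compounds go, is how far the result depends on the ether oxygen, which 2-hydroxyethyl, 3-methoxypropyl and 2-aminoethyl chains would probe.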